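The source may hold more compounds than are shown below. What is called first, only, known or untested is meant among the compounds shown, and "the series" means these compounds.

Measured so far in a functional assay on MKN-74 cells (Homo sapiens) for antiproliferative activity, with a stated time of 24 h; a lower number here means a stronger inhibitor, a higher number a weaker inhibitor:

Compound 1 `NC(=O)c1c(NC(=O)c2ccccc2Cl)sc2c1CCN(C(=S)Nc1ccccc1F)C2` gives 12600 nM in this assay.
Compound 2 `Cc1ccccc1NC(=S)N1CCc2c(sc(NC(=O)c3ccccc3Cl)c2C(N)=O)C1` gives 11700 nM in this assay.

Compound 2 shows the lowest of the two numbers, but its nearest neighbour, compound 1, lies within the scatter: a 1.1-fold lower number from compound 1 to compound 2 (0.03 log units; within the scatter), so the two compounds cannot be told apart in this assay.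

Compound 3 `NC(=O)c1c(NC(=O)c2ccccc2Cl)sc2c1CCN(C(=S)Nc1c(Cl)cccc1Cl)C2` has not yet been measured. It differs from compound 2 in one place: 2,6-dichlorophenyl in place of 2-methylphenyl on an amide-type nitrogen. For the measured compounds named here, the only measured step, from compound 1 to compound 2, also touches this aromatic ring on the thiourea side, exchanging fluoro for methyl, and it amounted to a 1.1-fold lower number from compound 1 to compound 2 (0.03 log units; within the scatter), a change within the scatter. Going by the values given here, that step offers no evidence that substitution on this ring moves the number far in either direction, and no measured pair speaks to a second chlorine or to 2,6-dichlorophenyl in particular. The step of a 1.2-fold lower number from compound 2 to compound 3 (0.07 log units; within the scatter) is therefore expected to stay small, with no direction beyond the scatter. Compound 3 is estimated at 10000 nM, with a range from 4000 nM to 25000 nM.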

Compound 3, half-maximal inhibitory concentration: 4020 nM
Beside the measured number, compound 3's estimate is 2.5-fold (0.40 log units) above it, within the range that was stated.
By their numbers in this assay, from the lowest: compound 3; then compounds 2 and 1 (each within the scatter of the next).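

In this assay, the aromatic group on the amide-type nitrogen next to the thiocarbonyl carbon can move the number beyond the scatter, which the exchange of fluoro for methyl had not shown with its a 1.1-fold lower number from compound 1 to compound 2 (0.03 log units; within the scatter) and which now appears with 2,6-dichlorophenyl. Replacing 2-methylphenyl with this group gives a 2.9-fold lower number from compound 2 to compound 3 (0.46 log units; beyond the scatter) and replacing 2-fluorophenyl with it gives a 3.1-fold lower number from compound 1 to compound 3 (0.50 log units; beyond the scatter) so the change is modest but points the same way from both earlier compounds, which themselves cannot be told apart. No measurement on any property of these groups is available to account for the difference.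

The compounds shown leave open whether the lower number needs both chlorine atoms, since 2-chlorophenyl or plain phenyl would be needed to separate the contribution of each. They also leave open whether 2,6-dimethylphenyl, 2,6-difluorophenyl or a ring carrying an amine or a carboxylic acid would follow compound 3 or fall back towards compound 1 and compound 2.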